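A Methoxy Added Where No Step Has Yet Been Measured

The source may report more compounds than this note shows. Statements on the series, on what has been measured and on what is new or still open speak of the compounds shown alone.

Within the data shown here, compound 1, `Cc1ccc(C(=O)NCC(=O)N/N=C/c2ccccc2OCc2ccccc2Cl)cc1`, is the only member of this small set with a measured number. In a functional assay on HepG2 cells (Homo sapiens) for inhibition, read by MTT assay, with a stated time of 24 h (on this read-out higher numbers stand for weaker inhibition and lower numbers for stronger inhibition), compound 1 gives 13400 nM. Compound 2, `O=C(CNC(=O)c1ccc(-c2ccccc2)cc1)N/N=C/c1ccccc1OCc1ccccc1Cl`, carries a phenyl in place of the methyl on an aromatic carbon of compound 1. In this assay compound 2 gives > 50000 nM, which is a limit of the assay and not a number. Among the measured compounds shown here, the single measured step, an at least 3.7-fold higher number from compound 1 to compound 2 (0.57 log units; beyond the scatter), thus ends at the limit described by the limit of > 50000 nM in this assay, at which 1 of the 2 values shown sits.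

Compound 3, `COc1ccc(/C=N/NC(=O)CNC(=O)c2ccc(C)cc2)c(OCc2ccccc2Cl)c1`, has not yet been measured. It differs from compound 1 by methoxy in place of hydrogen on an aromatic carbon. For the measured compounds named here, no measured step touches this place: the one step known, from compound 1 to compound 2, alters a different ring of the shared core, so it offers no direct guide to the size or direction of the change. Without a matching comparison, the step is expected to stay within the usual scatter of this assay, and the expected step is a 1.1-fold higher number from compound 1 to compound 3 (0.05 log units; within the scatter). Compound 3 is therefore estimated at 15000 nM, with a range from 5000 nM to 45000 nM.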

Compound 3, half-maximal inhibitory concentration: > 50000 nM
Compound 3 was reported as a limit; the forecaster's own chance of this, stated with the estimate: 15%; middle value at least 3.3-fold (0.52 log units) away from the limit.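

In this assay, among these compounds, methoxy in place of hydrogen is the first change measured at this place, on the aromatic carbon meta to a (2-chlorobenzyl)oxy group and para to a large group, and it brings an at least 3.7-fold higher number from compound 1 to compound 3 (0.57 log units; beyond the scatter). Compound 3 gives > 50000 nM, which is a limit of the assay and not a number, so the step has a known lower bound but no known full size. This place is therefore not a silent one: a group of only 2 heavy atoms moves the read-out beyond the scatter, in the direction of weaker inhibition, and a change here now ends at the same limit as the earlier change on a different ring of the shared core: the limit of > 50000 nM in this assay, at which 2 of the 3 values shown sit.

The compounds shown leave open whether this loss belongs to methoxy itself or to any group at this place, a question that a hydroxyl or a single fluorine atom here could help to settle. They also leave open whether methoxy on another carbon of the same ring would leave the read-out closer to that of compound 1.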